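Adding a Methylpiperazinyl Group to a Weakly Cytotoxic Amidine

The source may hold more compounds than are shown below. What is called first, only, known or untested is meant among the compounds shown, and "the series" means these compounds.

Of the compounds shown here, three sharing one core have been tested in an ADME assay on AG1523 cells (Homo sapiens) for cytotoxicity, read by MTT assay, with a stated time of 72 h; on this read-out lower numbers stand for stronger inhibition and higher numbers for weaker inhibition. Compound 1 `COc1ccc(Cn2nc(-c3ccccc3)c3cc(C(=N)Nc4ccc(N5CCN(C)CC5)cc4)nc(Nc4cc(OC)c(OC)c(OC)c4)c32)cc1` gives 1810 nM. Compound 2 `CN1CCN(c2ccc(NC(=N)c3cc4c(-c5ccccc5)n[nH]c4c(NC4CCCCC4)n3)cc2)CC1` gives 12300 nM. Compound 3 `COc1ccc(Cn2nc(-c3ccccc3)c3cc(C(=N)Nc4ccccc4)nc(NC4CCCCC4)c32)cc1` gives 26800 nM, the highest of the three numbers; its nearest neighbour is compound 2, whose number is lower by a margin beyond the scatter, and compound 1 lies furthest from it, also beyond the scatter. Compound 4 `COc1ccc(Cn2nc(-c3ccccc3)c3cc(C(=N)Nc4ccc(N5CCN(C)CC5)cc4)nc(NC4CCCCC4)c32)cc1` has not yet been measured in this assay. It differs from compound 3 in one place: 4-methylpiperazin-1-yl in place of hydrogen on an aromatic carbon, the 4-methylpiperazin-1-yl group entering on an aromatic carbon of a six-membered aromatic ring of carbon only, para to a large group. Compound 1 and compound 2 both carry this same group and both sit lower than compound 3, yet neither differs from compound 3 in only that place, so no single comparison isolates what the group alone contributes. Even so, the step of a 3.8-fold lower number from compound 3 to compound 4 (0.58 log units; beyond the scatter) is expected to lie beyond the scatter, in the direction of a lower number. The estimate for compound 4 is 7000 nM, within a range from 2500 nM to 20000 nM.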

Compound 4, half-maximal inhibitory concentration: 3330 nM
The estimate for compound 4 lay 2.1-fold (0.32 log units) above the measured number, within the range that was stated.
By their numbers in this assay, from the lowest: compounds 1 and 4 (each within the scatter of the next); then compound 2; then compound 3.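

In this assay, among the compounds shown here, the 4-methylpiperazin-1-yl group, entering on an aromatic carbon para to a large group, can now be read on its own for the first time: an 8.0-fold lower number from compound 3 to compound 4 (0.91 log units; beyond the scatter), a modest step that the earlier compounds could not isolate. With that group in place, two further single changes can also be read: 4-methoxybenzyl in place of hydrogen on the aromatic nitrogen goes with a 3.7-fold lower number from compound 2 to compound 4 (0.57 log units; beyond the scatter), whereas cyclohexyl in place of 3,4,5-trimethoxyphenyl on a nitrogen on an aromatic ring gives a 1.8-fold higher number from compound 1 to compound 4 (0.26 log units; within the scatter), so the two groups cannot be told apart at this position. No measurement available here accounts for any of these steps.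

On these data alone, whether a morpholin-4-yl group, an unsubstituted piperazin-1-yl group or a simple dimethylamino group on the same aromatic carbon would give a similar step remains open. Also open is whether the step from adding the 4-methylpiperazin-1-yl group carries over when 3,4,5-trimethoxyphenyl replaces cyclohexyl, since compound 1 has no partner among the compounds shown that lacks the group.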